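Cytotoxicity notes: from compound 2 to compound 4

A few compounds are considered here, and "the series" means these few. Any claim that something is new, unique, unknown or untested is made for them only; others in the source may bear on it.

Measured compounds:
compound 1, `COc1ccc(C(=O)CSc2nc(Cc3cccc(Br)c3)c(C)c(=O)[nH]2)cc1`: >= 196000 nM (a limit)
compound 2, `COc1ccc(C(=O)CSc2nc(Cc3cc(C(F)(F)F)cc(C(F)(F)F)c3)c(C)c(=O)[nH]2)cc1`: > 242000 nM (a limit)
compound 3, `Cc1c(Cc2cccc3ccccc23)nc(SCC(=O)c2ccccc2)[nH]c1=O`: >= 305000 nM (a limit)

In an ADME assay on MT4 cells (Homo sapiens) for cytotoxicity (on this read-out lower numbers stand for higher toxicity in this test and higher numbers for lower toxicity in this test), compound 2 gives > 242000 nM, which is a limit of the assay and not a number. Compound 1 likewise sits at a limit, (the limit of >= 196000 nM in this assay, at which 1 of the 3 values shown sits). Compound 3 also sits at a limit, (the limit of >= 305000 nM in this assay, at which 1 of the 3 values shown sits). Compound 2 itself stands at the limit of > 242000 nM in this assay, at which 1 of the 3 values shown sits. None of the three values is a measured number, so no ordering among compounds 1, 2 and 3 can be read from them; all three show only that no cytotoxicity was reached within the tested range.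

Compound 4, `CCc1c(Cc2cc(C(F)(F)F)cc(C(F)(F)F)c2)nc(SCC(=O)c2ccc(OC)cc2)[nH]c1=O`, is not yet measured. It differs from compound 2 by methyl in place of hydrogen on a saturated chain carbon bound to an aromatic carbon. The rest of the structure is unchanged.

Among the compounds with values here, no step between measured compounds exists to calibrate this change. The expectation is a step from compound 2 to compound 4 of a step that the limit leaves unreadable from compound 2 to compound 4, that is, none beyond the usual scatter, and most likely again a limit rather than a number. For compound 4 the estimated value in this assay is 250000 nM, with a range from 100000 nM to 600000 nM.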

Compound 4, half-maximal cytotoxic concentration: > 236000 nM
Compound 4 was reported as a limit; the forecaster's own chance of this, stated with the estimate: 80%; the middle value lies beyond the limit too.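

In this assay compound 4 gives > 236000 nM, which is a limit and not a number. Within the data shown here, compound 2 gives > 242000 nM, also a limit, so no step between compound 2 and compound 4 can be read. The compounds shown leave open whether methyl in place of hydrogen at this place changes cytotoxicity at all.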